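Notes on replacing isopropoxy in compound 1

The source may hold more compounds than are shown below. What is called first, only, known or untested is meant among the compounds shown, and "the series" means these compounds.

Compound 1 `CC(C)OC(=O)Nc1ncc(SCc2ncc(C(C)(C)C)o2)s1` gives 640 nM
Compound 2 `CC(C)(C)c1cnc(CSc2cnc(NS(=O)(=O)c3ccccc3)s2)o1` gives 2860 nM

In a functional assay on A2780 cells (Homo sapiens) for cytotoxicity (on this read-out higher numbers stand for weaker inhibition and lower numbers for stronger inhibition), compound 1 holds the lower of the two numbers at 640 nM while compound 2 gives 2860 nM in a gap beyond the scatter. For the measured compounds named here, no step in a single place joins these two, so their gap cannot be tied to any one change.

The next compound is compound 3 `CC(C)(C)c1cnc(CSc2cnc(NC(=O)Nc3c(Cl)cccc3Cl)s2)o1` in which (2,6-dichlorophenyl)amino stands in place of isopropoxy on a carbonyl carbon. The change from compound 1 counts as (2,6-dichlorophenyl)amino in place of isopropoxy on a carbonyl carbon and the rest of the structure stays the same.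

Going by the values given here, no measured step covers this exchange. The expectation therefore starts from compound 1 at 640 nM and keeps a wide upper side, as compound 2 reaches 2860 nM with a different group on the shared core. The expected step in this assay is small and toward a higher number, estimated as a 1.6-fold higher number from compound 1 to compound 3 (0.19 log units; within the scatter) and so within the scatter. The estimate for compound 3 is 1000 nM with an expected range from 250 nM to 4000 nM on this read-out.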

Compound 3, half-maximal inhibitory concentration: 1500 nM
The estimate for compound 3 lay 1.5-fold (0.18 log units) below the measured number; the range from low to high includes it.
By their numbers in this assay, from the lowest: compound 1; then compounds 3 and 2 (each within the scatter of the next).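

For the compounds shown here, the exchange gives the first step that can be tied to one place: in this assay, (2,6-dichlorophenyl)amino in place of isopropoxy on a carbonyl carbon gives a 2.3-fold higher number from compound 1 to compound 3 (0.37 log units; beyond the scatter) and so counts as a modest change beyond the scatter. The position therefore accepts a group with more heavy atoms, a six-membered aromatic ring and a hydrogen-bond donor while the number rises only modestly, and the smaller isopropoxy holds the lower number of this pair. Going by these compounds alone, nothing measured on these compounds accounts for the step, and ring, size and donor count all change in the one exchange.

From the compounds shown here alone, it remains open whether the rise goes with the amino link, the phenyl ring or its two chlorines, which phenylamino, methylamino or phenoxy on the same carbonyl carbon could help to separate. Going by these compounds, it also remains open how much the lower number of compound 1 depends on the branching of isopropoxy, a question that ethoxy or tert-butoxy at this place would address.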